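A few compounds are considered here, and "the series" means these few. Any claim that something is new, unique, unknown or untested is made for them only; others in the source may bear on it.

Compound 3 `CC(C)C(=O)N1CCC[C@H]1C(=O)N1CCC(NS(=O)(=O)c2cc(S(=O)(=O)c3ccccc3)ccc2C(F)(F)F)CC1` gives 90 nM in a functional assay on U2OS cells for antagonist activity at proto-oncogene Wnt-3 (Homo sapiens), read by a luciferase reporter, with a stated time of 18 h; on this read-out higher numbers stand for an effect only at larger amounts of compound and lower numbers for an effect already at smaller amounts. Among the three measured compounds it stands second highest: compound 2 `CC(C)(C)OC(=O)N1CCC[C@H]1C(=O)N1CCC(NS(=O)(=O)c2cc(S(=O)(=O)c3ccccc3)ccc2C(F)(F)F)CC1` gives 60 nM, and the two values lie within the scatter of each other, while compound 1 `CN(C)CC(=O)N1CCC(NS(=O)(=O)c2cc(S(=O)(=O)c3ccccc3)ccc2C(F)(F)F)CC1` gives 280 nM, the highest of the three. The step of a 3.1-fold lower number from compound 1 to compound 3 (0.49 log units; beyond the scatter) and the step of a 4.7-fold lower number from compound 1 to compound 2 (0.67 log units; beyond the scatter) both reach beyond the scatter, whereas the step of a 1.5-fold higher number from compound 2 to compound 3 (0.18 log units; within the scatter) does not.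

Compound 4 `CCNC(=O)N1CCC[C@H]1C(=O)N1CCC(NS(=O)(=O)c2cc(S(=O)(=O)c3ccccc3)ccc2C(F)(F)F)CC1` differs from compound 3 only at one point: ethylamino in place of isopropyl on a carbonyl carbon. Among the compounds with values here, the one measured step that bears on this site is a 1.5-fold higher number from compound 2 to compound 3 (0.18 log units; within the scatter), which exchanged one group on that same carbonyl carbon for another and stayed within the scatter. On that basis compound 4 is expected to show no step beyond the scatter in this assay, the estimated step being no change at the digits printed from compound 3 to compound 4 (within the scatter). The estimate for compound 4 is 90 nM, with a range from 35 nM to 230 nM.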

Compound 4, half-maximal effective concentration: 90 nM
Compound 4: the middle estimate sits on the measured number at the digits printed; the range from low to high includes it.
By their numbers in this assay, from the lowest: compounds 2, 3 and 4 (each within the scatter of the next); then compound 1.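

In this assay the ethylamino group brings a hydrogen-bond donor and a nitrogen to the carbonyl carbon, yet the data show no change at the digits printed from compound 3 to compound 4 (within the scatter) and a 1.5-fold higher number from compound 2 to compound 4 (0.18 log units; within the scatter) as the outcome, so tert-butoxy, isopropyl and ethylamino at this place all lie within the scatter of one another. With a 3.1-fold lower number from compound 1 to compound 4 (0.49 log units; beyond the scatter) as its step, 1-(ethylcarbamoyl)pyrrolidin-2-yl also stands beyond the scatter from (dimethylamino)methyl on a carbonyl carbon, as the other two 1-substituted pyrrolidin-2-yl groups do. No measurement here explains why the added donor leaves the number where it is.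

The compounds shown leave open how far this tolerance extends. A primary amine, a carboxylic acid or a longer alkyl chain on the same carbonyl carbon could still move the number beyond the scatter.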